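The compounds below may be only part of what the source reports. "The series", "measured", "known", "first", "only" and "open" are said of these compounds alone.

Measured in a functional assay on HeLa cells (Homo sapiens) for inhibition, read by sulforhodamine B assay; a lower number here means a stronger inhibitor, a higher number a weaker inhibitor:
- Compound 1 `CCCc1ccc(NC2=CC(=O)c3nc4n(c3C2=O)[C@H]2OC[C@@H](O)[C@H]2OC4)cc1`: 4990 nM
- Compound 2 `O=C1C(Nc2ccccc2)=CC(=O)c2c1nc1n2[C@H]2OC[C@@H](O)[C@H]2OC1`: > 8000 nM

Compound 2 gives > 8000 nM, which is a limit of the assay and not a number. For the measured compounds named here, the pair therefore offers only one true number: the limit of > 8000 nM in this assay, at which 1 of the 2 values shown sits. Compound 3 `O=C1C(Nc2ccc(Br)cc2)=CC(=O)c2c1nc1n2[C@H]2OC[C@@H](O)[C@H]2OC1` keeps the core of compound 2 and changes it in one place, with bromo in place of hydrogen on an aromatic carbon, para to a large group, turning phenyl to 4-bromophenyl (bromo in place of hydrogen on an aromatic carbon). Going by the values given here, no measured pair here tests this change, so any expectation remains loose. Compound 1 at 4990 nM gives the only measured level in this assay, and the expectation is anchored there. The estimated step of an at least 1.4-fold lower number from compound 2 to compound 3 (0.16 log units; that floor lies within the scatter) is modest and toward stronger inhibition. For compound 3 the estimate is 5500 nM, with an expected range from 2000 nM to 14000 nM.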

Compound 3, half-maximal inhibitory concentration: 5220 nM
For compound 3 the middle estimate is 1.1-fold (0.02 log units) above the measured one; the measured number falls inside the stated range.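

In this assay, bromo in place of hydrogen on the aromatic carbon, para to a large group, turns phenyl to 4-bromophenyl, and compound 3 gives 5220 nM as a measured number at this position. For compound 2 the value > 8000 nM is a limit of the assay and not a number. The change can therefore be read only as an at least 1.5-fold lower number from compound 2 to compound 3 (0.18 log units; that floor lies within the scatter) and its true size stays unfixed, because one end of the step rests on a limit: the limit of > 8000 nM in this assay, at which 1 of the 3 values shown sits.

As far as these compounds go, how far compound 2 really lies from compound 3 remains open. Also open, from the compounds shown here alone, is whether an amine, a carboxylic acid or a longer chain in place of bromo on the same carbon would move the number in either direction.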